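The source may hold more compounds than are shown below. What is called first, only, known or untested is meant among the compounds shown, and "the series" means these compounds.

Measured so far in a functional assay on HCT-116 cells (Homo sapiens) for cytotoxicity, read by scintillation counting and thymidine incorporation, with a stated time of 72 h; on this read-out higher numbers stand for weaker inhibition and lower numbers for stronger inhibition: compound 1 `CCOc1cc(C(=CC#N)c2cc(OC)cc(OC)c2)ccc1OC` gives 34 nM; compound 2 `CCOc1cc(C(=CC#N)c2cccc(OC)c2)ccc1OC` gives 450 nM; compound 3 `COc1ccc(C(=CC#N)c2cc(OC)c(OC)c(OC)c2)cc1OC` gives 41 nM.

Compounds 1 and 2 differ in one place, (hydrogen in place of methoxy on an aromatic carbon), and this change made a 13-fold higher number from compound 1 to compound 2 (1.12 log units; beyond the scatter). Compound 3 carries a core whose difference from the core of compound 1 is not broken down here. Compound 4 `COc1ccc(C(=CC#N)c2ccc(OC)c(OC)c2)cc1OC` is compound 3 with the same kind of change, (hydrogen in place of methoxy on an aromatic carbon). The surroundings are not identical: in compound 4 the place is also ortho to a methoxy group, which it was not in compound 2, so the two changes are alike but not the same. Because of the step of a 13-fold higher number from compound 1 to compound 2 (1.12 log units; beyond the scatter), compound 4 is expected to show an 11-fold higher number from compound 3 to compound 4 (1.04 log units; beyond the scatter) in this assay. The estimate for compound 4 is 450 nM, likely between 120 nM and 1500 nM.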

Compound 4, half-maximal inhibitory concentration: 140 nM
Compound 4: middle estimate off by 3.2-fold (0.51 log units), on the high side; the range from low to high includes it.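

In this assay, putting hydrogen in place of methoxy weakens inhibition on the second core as well, with a 3.4-fold higher number from compound 3 to compound 4 (0.53 log units; beyond the scatter), so the direction of the change carries over between these two pairs. The size does not carry over: the same change on two cores in this assay, a 13-fold higher number (1.12 log units; beyond the scatter) from compound 1 to compound 2 and a 3.4-fold higher number (0.53 log units; beyond the scatter) from compound 3 to compound 4, 3.9-fold (0.59 log units) apart, beyond the scatter of two such steps. These two pairs cannot show why the sizes differ, although in compound 4 the place is also ortho to a methoxy group, and they cannot predict the size of the step on any further core.

Only methoxy and hydrogen are compared at this place. The compounds shown leave open how a hydroxyl group, an amine or a fluorine atom there would change the result on either core.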